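A few compounds are considered here, and "the series" means these few. Any claim that something is new, unique, unknown or untested is made for them only; others in the source may bear on it.

Compound 1 `COc1cc(/C=C/C(=O)c2cccc(-n3cc(-c4ccc(Cl)cc4)[nH]c3=O)c2)ccc1O` and compound 2 `COc1cc(/C=C/C(=O)c2cccc(-n3cc(-c4ccccc4)[nH]c3=O)c2)ccc1O` share a core and differ only in that compound 2 carries hydrogen in place of chloro on an aromatic carbon. In a functional assay on SF-295 cells (Homo sapiens) for inhibition (on this read-out higher numbers stand for weaker inhibition of growth and lower numbers for stronger inhibition of growth), compound 1 gives 10500 nM, while compound 2 gives 3040 nM, the lowest of the two numbers; the step of a 3.5-fold lower number from compound 1 to compound 2 (0.54 log units; beyond the scatter) was modest but lies beyond the scatter. Compound 3 `O=C(/C=C/c1cccc(O)c1)c1cccc(-n2cc(-c3ccccc3)[nH]c2=O)c1` is not yet measured. It differs from compound 2 by 3-hydroxyphenyl in place of 4-hydroxy-3-methoxyphenyl on a double-bonded chain carbon bound to a double-bonded chain carbon. Among the compounds with values here, no measured step touches this part of the molecule: the only step recorded, from compound 1 to compound 2, concerns the other aromatic ring, so it gives no direct guide to the change made here. Without a step bearing on the change, compound 3 is expected to land close to compound 2, with a step of a 1.2-fold higher number from compound 2 to compound 3 (0.06 log units; within the scatter) not clearly beyond the scatter. For compound 3 the estimate in this assay is 3500 nM, with a range from 1000 nM to 12000 nM.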

Compound 3, concentration for 50% growth inhibition: 18200 nM
Compound 3: the middle estimate sits 5.2-fold (0.72 log units) below what was measured, outside the stated range (above it).
By their numbers in this assay, from the lowest: compound 2; then compounds 1 and 3 (each within the scatter of the next).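

Replacing 4-hydroxy-3-methoxyphenyl with 3-hydroxyphenyl on the double-bonded chain carbon gives, in this assay, a 6.0-fold higher number from compound 2 to compound 3 (0.78 log units; beyond the scatter), so growth inhibition depends on this part of the molecule as well as on the other aromatic ring, where the earlier step was a 3.5-fold lower number from compound 1 to compound 2 (0.54 log units; beyond the scatter). The group that enters keeps the single hydrogen-bond donor of the group that leaves but has one hydrogen-bond acceptor rather than two, and weaker inhibition of growth goes with this change in these two compounds. No measurement shown here explains the loss.

The compounds shown do not separate the loss of the methoxy group from the different place of the hydroxy group on the ring. As far as these compounds go, it remains open how a 4-hydroxyphenyl group or a 3-aminophenyl group on this chain carbon would compare with compound 2.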